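Para-substituted anilides of a pyridine carboxylic acid core

The source may report more compounds than this note shows. Statements on the series, on what has been measured and on what is new or still open speak of the compounds shown alone.

Measured compounds:
compound 1 `O=C(Nc1ccccc1)c1ccc(C(=O)O)nc1`: 26500 nM
compound 2 `Cc1ccc(NC(=O)c2ccc(C(=O)O)nc2)cc1`: 8300 nM
compound 3 `CN(C)c1ccc(NC(=O)c2ccc(C(=O)O)nc2)cc1`: 4100 nM

Compound 3 gives the lowest number of the three in an assay on isolated protein (Gallus gallus) for inhibition of transmembrane prolyl 4-hydroxylase (Homo sapiens); a higher number here means a weaker inhibitor, a lower number a stronger inhibitor. Compound 2 stands nearest, a 2.0-fold lower number from compound 2 to compound 3 (0.31 log units; beyond the scatter), and compound 1 furthest, a 6.5-fold lower number from compound 1 to compound 3 (0.81 log units; beyond the scatter). Compound 4 `O=C(Nc1ccc([N+](=O)[O-])cc1)c1ccc(C(=O)O)nc1` is not yet measured; it differs from compound 3 as follows: nitro in place of dimethylamino on an aromatic carbon.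

Among the compounds with values here, two measured steps bear on this position. Replacing hydrogen at the same place by methyl gave a 3.2-fold lower number from compound 1 to compound 2 (0.50 log units; beyond the scatter), and by dimethylamino gave a 6.5-fold lower number from compound 1 to compound 3 (0.81 log units; beyond the scatter). Within the data shown here, no step with nitro at this position exists, so its effect cannot be read from the data. Both substitutions on this aromatic carbon so far lowered the number, but compound 3 holds the best value, and a third group may well sit between compound 1 and compound 3.

Compound 4 is therefore expected to give a modestly higher number than compound 3 in this assay, estimated at 9000 nM with a range from 2500 nM to 30000 nM. This estimate means a step of a 2.2-fold higher number from compound 3 to compound 4 (0.34 log units; beyond the scatter), expected to lie at or just beyond the scatter.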

Compound 4, half-maximal inhibitory concentration: 44000 nM
For compound 4 the middle estimate is 4.9-fold (0.69 log units) below the measured one; the measured number lies above the stated range.
By their numbers in this assay, from the lowest: compound 3; then compound 2; then compounds 1 and 4 (each within the scatter of the next).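

Nitro is the first group at this aromatic carbon that does not lower the number in this assay, since its step from hydrogen stays within the scatter (a 1.7-fold higher number from compound 1 to compound 4 (0.22 log units; within the scatter)). Within the data shown here, the position is also more sensitive than the earlier compounds showed: replacing dimethylamino with nitro (an 11-fold higher number from compound 3 to compound 4 (1.03 log units; beyond the scatter)) gives the largest step, and replacing methyl with nitro (a 5.3-fold higher number from compound 2 to compound 4 (0.72 log units; beyond the scatter)) also lies beyond the scatter. The earlier gain on substitution therefore depends on the group, with dimethylamino and methyl lowering the number and nitro leaving it level with hydrogen.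

No measurement shown accounts for this spread. Where a methoxy group, a primary amine or a chlorine atom would fall at this carbon remains open, as does the effect of nitro elsewhere on the ring.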